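The compounds below may be only part of what the source reports. "The series", "measured", "known", "first", "only" and "open" are said of these compounds alone.

Working notes on the series. Compound 1 `Cc1ccc(Oc2ccc3nc(COc4cccc(C(=O)O)c4)n(C)c3c2)nc1C` gives 7.7 10^-6 cm/s in an ADME assay for permeability, using PAMPA, with a stated time of 4 h; on this read-out higher numbers stand for higher permeability and lower numbers for lower permeability. Compound 2 `Cc1cnc(Oc2ccc3nc(COc4cccc(C(=O)O)c4)n(C)c3c2)c(F)c1` gives 5.8 10^-6 cm/s in this assay, and compound 3 `Cc1cc(F)cnc1Oc1ccc2nc(COc3cccc(C(=O)O)c3)n(C)c2c1` gives 8.3 10^-6 cm/s. The three numbers lie within the scatter of one another: a 1.3-fold lower number from compound 1 to compound 2 (0.12 log units; within the scatter), a 1.1-fold higher number from compound 1 to compound 3 (0.03 log units; within the scatter) and a 1.4-fold higher number from compound 2 to compound 3 (0.16 log units; within the scatter); so no order among compound 1, compound 2 and compound 3 is established, even though the number for compound 3 is the largest of the three.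

Compound 4 `Cc1cc(Cl)cnc1Oc1ccc2nc(COc3cccc(C(=O)O)c3)n(C)c2c1` has not yet been measured. Its difference from compound 3 is chloro in place of fluoro on an aromatic carbon. For the measured compounds named here, no measured step exchanges fluoro for chloro; the measured steps all rearrange the methyl and fluoro substituents on the same pyridinyl group, and every one of them stayed within the scatter. On that basis no step beyond the scatter is expected in this assay for compound 4, as a 1.1-fold higher number from compound 3 to compound 4 (0.04 log units; within the scatter). The estimate for compound 4 is 9 10^-6 cm/s, with a range from 5 10^-6 cm/s to 16 10^-6 cm/s.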

Compound 4, apparent permeability: 13.7 10^-6 cm/s
Compound 4: middle estimate off by 1.5-fold (0.18 log units), on the low side; the range from low to high includes it.
By their numbers in this assay, from the lowest: compounds 2, 1, 3 and 4 (each within the scatter of the next, the first and the last beyond it).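

In this assay the exchange of fluoro for chloro on this aromatic carbon, two atoms from the ring nitrogen and para to a large group, gives a 1.7-fold higher number from compound 3 to compound 4 (0.22 log units; within the scatter) and so is not separated from the scatter on its own. The series now holds one step beyond the scatter in a 2.4-fold higher number from compound 2 to compound 4 (0.37 log units; beyond the scatter) while a 1.8-fold higher number from compound 1 to compound 4 (0.25 log units; within the scatter) stays within it; the step beyond the scatter exchanges the whole substituted pyridinyl group, so it does not isolate the chloro. No measurement at hand accounts for any of these steps.

Going by these compounds, whether bromo, methoxy or a nitrile at this position would stand apart from fluoro and chloro stays open. Also open, on these data alone, is whether the same exchange of fluoro for chloro would give a similar step on the 3-fluoro-5-methylpyridin-2-yl group.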